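From Acetamide to Pyridinylamine on a Shared Core

The source may report more compounds than this note shows. Statements on the series, on what has been measured and on what is new or still open speak of the compounds shown alone.

Compound 1 `Cc1c(C)c2c(c(C)c1N)CC(C)(CSc1ccccc1)O2`: 24.7 mg/kg
Compound 2 `Cc1c(C)c2c(c(C)c1N)CC(C)(CNCc1ccccc1)O2`: 9.1 mg/kg
Compound 3 `CC(=O)Nc1c(C)c(C)c2c(c1C)CC(C)(C)O2`: > 100 mg/kg

In a functional assay on the whole organism with Mus musculus as the target (on this read-out lower numbers stand for an effect already at smaller amounts and higher numbers for an effect only at larger amounts of compound), the three measured compounds do not sit together. Compound 1 gives 24.7 mg/kg and compound 2 gives 9.1 mg/kg. For compound 3 the assay reports no number, only a limit, > 100 mg/kg. From the compounds shown here alone, compound 3 therefore stands at the limit of > 100 mg/kg in this assay, at which 1 of the 3 values shown sits, so its true dose is unknown beyond that boundary.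

Compound 4 `Cc1c(C)c2c(c(C)c1Nc1cccnc1)CC(C)(C)O2` differs from compound 3 in a single place: pyridin-3-yl in place of acetyl on a nitrogen on an aromatic ring. Going by the values given here, no step between measured compounds is available to set the size of this change. What the measured compounds show is that compound 1 and compound 2, whose aromatic nitrogen carries neither of these two groups, reach their effect at doses inside the tested range, while compound 3 does not.

Compound 4 is expected to fall at 45 mg/kg, with a range from 15 mg/kg to 100 mg/kg. This expectation corresponds to an estimated step of an at least 2.2-fold lower number from compound 3 to compound 4 (0.34 log units; beyond the scatter), toward lower doses, though a renewed limit is not excluded.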

Compound 4, dose for 50% inhibition: > 50 mg/kg
Compound 4: only a limit was reported; the forecaster's own chance of this, stated with the estimate: 35%; middle value at least 1.1-fold (0.04 log units) away from the limit.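

Going by these compounds alone, compound 3 and compound 4 are each reported only as a limit, not as a number, so no step between the two can be read. The compounds shown leave open whether pyridin-3-yl in place of acetyl changes the dose at all, and in which direction.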